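Amide to urea at the anilide carbonyl: growth inhibition

A few compounds are considered here, and "the series" means these few. Any claim that something is new, unique, unknown or untested is made for them only; others in the source may bear on it.

Measured compounds:
compound 1 `COc1cc(-c2nn(-c3cccc(NC(=O)c4cccc(C(F)(F)F)c4)c3)cc2-c2ccncc2)ccc1Cl`: 1090 nM
compound 2 `O=C(Nc1cccc(-n2cc(-c3ccncc3)c(-c3ccc(Cl)c(O)c3)n2)c1)Nc1cc(C(F)(F)F)cc(C(F)(F)F)c1`: 1070 nM

In a functional assay on NCI/ADR-RES cells (Homo sapiens) for inhibition, read by sulforhodamine B assay, with a stated time of 48 h (on this read-out higher numbers stand for weaker inhibition of growth and lower numbers for stronger inhibition of growth), compound 1 gives 1090 nM, the higher of the two numbers, and compound 2 gives 1070 nM, within the scatter of compound 1. Going by the values given here, no measured pair differs in a single place, so no step size is known. Compound 3 `COc1cc(-c2nn(-c3cccc(NC(=O)Nc4ccc(Cl)c(Cl)c4)c3)cc2-c2ccncc2)ccc1Cl` carries (3,4-dichlorophenyl)amino in place of 3-(trifluoromethyl)phenyl on a carbonyl carbon. Because compound 2 gives 1070 nM in this assay, a different carbonyl substituent on the same core has not moved the read-out. The step of a 1.2-fold lower number from compound 1 to compound 3 (0.08 log units; within the scatter) is expected to stay within the scatter, with no firm direction. Compound 3 is estimated at 900 nM (range 300 nM to 3000 nM).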

Compound 3, concentration for 50% growth inhibition: 990 nM
The estimate for compound 3 lay 1.1-fold (0.04 log units) below the measured number; the range from low to high includes it.
By their numbers in this assay, from the lowest: compounds 3, 2 and 1 (each within the scatter of the next).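

In this assay, going by these compounds alone, the change from 3-(trifluoromethyl)phenyl to (3,4-dichlorophenyl)amino on a carbonyl carbon gives a 1.1-fold lower number from compound 1 to compound 3 (0.04 log units; within the scatter) and is the only single-place step available. On the core of compound 1, this read-out therefore does not separate the (3-(trifluoromethyl)phenyl)carbonyl and (3,4-dichlorophenyl)carbamoyl groups. No measurement on hand explains this result.

Open, on these data alone, is whether a carbonyl substituent without an aromatic ring, such as a morpholine or a simple methyl group, would keep the number in this range.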